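Two acids in place of one alcohol on the amide nitrogen

The source may report more compounds than this note shows. Statements on the series, on what has been measured and on what is new or still open speak of the compounds shown alone.

Compound 1, `CCn1c(C(=O)N[C@H](CO)C(C)C)ccc1C(CC)(CC)c1ccc(OCS(=O)(=O)c2ccccc2)c(C)c1`, is the starting point of this comparison. Within the data shown here, in a functional assay on PC-3 cells (Homo sapiens) for antiproliferative activity, read by MTT assay, with a stated time of 24 h (on this read-out higher numbers stand for weaker inhibition and lower numbers for stronger inhibition), compound 1 gives 7300 nM, the highest of the two numbers measured so far, meaning the weakest inhibition of the pair. Its nearest neighbour is compound 2, `CCn1c(C(=O)N[C@@H](C(=O)O)C(C)C)ccc1C(CC)(CC)c1ccc(OCS(=O)(=O)c2ccccc2)c(C)c1`, which differs only in that 1-carboxy-2-methylpropyl replaces 1-(hydroxymethyl)-2-methylpropyl on the amide-type nitrogen; in this assay compound 2 gives 3070 nM. Among the measured compounds shown here, that one measured step, a 2.4-fold lower number from compound 1 to compound 2 (0.38 log units; beyond the scatter), is the only guide available here.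

The new compound 3, `CCn1c(C(=O)N[C@@H](CCC(=O)O)C(=O)O)ccc1C(CC)(CC)c1ccc(OCS(=O)(=O)c2ccccc2)c(C)c1`, changes the same position of compound 1: 1,3-dicarboxypropyl in place of 1-(hydroxymethyl)-2-methylpropyl on an amide-type nitrogen. This again exchanges the hydroxymethyl for a carboxy group and adds a second carboxy group on a longer chain, so the measured step from compound 1 to compound 2 is the one that bears on it. For the measured compounds named here, a modest lowering of a similar size is therefore expected, though no measured step covers the second carboxy group. The estimated step is a 2.1-fold lower number from compound 1 to compound 3 (0.32 log units; beyond the scatter). For compound 3 the expected value is 3500 nM, within a range of 1500 nM to 8500 nM.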

Compound 3, half-maximal inhibitory concentration: > 50000 nM
Compound 3 ended at the assay's limit; the forecaster's own chance of this, stated with the estimate: 5%; middle value at least 14-fold (1.15 log units) away from the limit.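

In this assay compound 3 gives > 50000 nM, which is a limit of the assay and not a number: the limit of > 50000 nM in this assay, at which 1 of the 3 values shown sits. The position that allowed a modest improvement with 1-carboxy-2-methylpropyl turns sharply the other way with 1,3-dicarboxypropyl, giving an at least 6.8-fold higher number from compound 1 to compound 3 (0.83 log units; beyond the scatter), and, measured against the single-acid side chain, an at least 16-fold higher number from compound 2 to compound 3 (1.21 log units; beyond the scatter). The presence of a carboxy group on the amide-type nitrogen therefore does not decide the outcome on its own, since compound 2 and compound 3 both carry one and still lie far apart.

The compounds shown do not separate the effect of adding the second carboxylic acid from the effect of losing the branched 2-methylpropyl end, since both changes arrive together in compound 3. As far as these compounds go, a side chain of the same length ending in a primary amide or a methyl ester instead of the second carboxylic acid would help to tell these apart, and how far compound 3 lies past its limit also remains open.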